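A few compounds are considered here, and "the series" means these few. Any claim that something is new, unique, unknown or untested is made for them only; others in the source may bear on it.

Compound 1 `Cc1c(/C=N\O)cc(-c2ccc(S(C)(=O)=O)cc2)n1-c1ccc(F)c(F)c1` and compound 2 `Cc1c(/C=N\O)cc(-c2ccc(S(C)(=O)=O)cc2)n1-c1ccccc1` share one core and differ only in the group on an aromatic nitrogen. In a functional assay on the whole organism (strain Swiss albino) for inhibition, with Mus musculus as the target, in the writhing test, with a stated time of 30 min, at a dose of 10 mg/kg by the oral route (on this read-out lower numbers stand for a weaker effect and higher numbers for a stronger effect at the one dose given), compound 1 gives 19%. In this assay compound 2 gives 27%. The change between them, (phenyl in place of 3,4-difluorophenyl on an aromatic nitrogen), made a step of a number 8 percentage points higher from compound 1 to compound 2 (within the scatter). Compound 3 `Cc1c(C#N)cc(-c2ccc(S(C)(=O)=O)cc2)n1-c1ccc(F)c(F)c1` carries a second core; how it differs from compound 1 is a group of 2 heavy atoms (1 carbon, 1 nitrogen; no ring) in place of a group of 3 heavy atoms (1 carbon, 1 nitrogen, 1 oxygen; no ring), on an aromatic carbon, a change that gave no change at the digits printed from compound 1 to compound 3 (within the scatter). In this assay compound 3 gives 19%. Compound 4 `Cc1c(C#N)cc(-c2ccc(S(C)(=O)=O)cc2)n1-c1ccccc1` has not been measured. For the measured compounds named here, it differs from compound 3 by phenyl in place of 3,4-difluorophenyl on an aromatic nitrogen, which is the same kind of change as the one from compound 1 to compound 2; what differs around the place is that the ring atom two ring bonds from it bears a cyano group (2 heavy atoms) in compound 3, where in compound 1 that ring atom bears a group of 3 heavy atoms. The expectation for compound 4 rests on two measured facts: the same kind of change on the aromatic nitrogen gave a number 8 percentage points higher from compound 1 to compound 2 (within the scatter), and the change of core from compound 1 to compound 3 gave no change at the digits printed from compound 1 to compound 3 (within the scatter), so the second core is not expected to answer differently. Compound 4 is therefore expected to show a number 7 percentage points higher from compound 3 to compound 4 (within the scatter). Compound 4 is estimated at 26%, with the likely range from 12% to 40%.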

Compound 4, a percentage reported as inhibition, in the whole organism at one dose (the size of the read-out at that dose, not a potency): 28%
Compound 4: middle estimate off by 2 percentage points, on the low side; the measured number falls inside the stated range.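

On the second core, phenyl in place of 3,4-difluorophenyl on the aromatic nitrogen gave a number 9 percentage points higher from compound 3 to compound 4 (within the scatter) in this assay, and set beside the earlier step it reads the same: the same change on two cores in this assay, a number 8 percentage points higher (within the scatter) from compound 1 to compound 2 and a number 9 percentage points higher (within the scatter) from compound 3 to compound 4, 1 percentage points apart, within the scatter of two such steps

With phenyl on the aromatic nitrogen, the cyano group in place of the group of 3 heavy atoms gave a number 1 percentage points higher from compound 2 to compound 4 (within the scatter), which also matches its earlier counterpart: the same change on two cores in this assay, no change at the digits printed (within the scatter) from compound 1 to compound 3 and a number 1 percentage points higher (within the scatter) from compound 2 to compound 4, 1 percentage points apart, within the scatter of two such steps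

So among these four compounds, neither change answers differently on one core than on the other in this assay, but every step lies within the scatter, so the agreement does not show that either change has a real effect on the read-out, and it says nothing about other doses, other assays or other compounds.

The compounds shown leave open how the read-out would respond to a different group on the aromatic nitrogen, such as a chlorophenyl or a longer alkyl chain. They also leave open what an amine or a carboxylic acid would do on the ring atom that bears the cyano group in compound 4.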